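Methoxy added on the aryl ketone ring of compound 3

This account rests on a few compounds, and the source may have more. Where it says the series, first, only, none or still open, it means among the compounds named here.

Measured compounds:
- compound 1, `COc1cc(OC)c2sc(-c3ccc(N/C=C\C(=O)c4ccc(OC)c([N+](=O)[O-])c4)c(C)c3)nc2c1`: 13900 nM
- compound 2, `COc1ccc(C(=O)/C=C\Nc2ccc(-c3nc4cc(OC)c(OC)c(OC)c4s3)cc2C)cc1[N+](=O)[O-]`: 23400 nM
- compound 3, `COc1ccc2nc(-c3ccc(N/C=C\C(=O)c4ccc(OC)c([N+](=O)[O-])c4)cc3)sc2c1`: 23600 nM

In a functional assay on MIA PaCa-2 cells (Homo sapiens) for antiproliferative activity, read by sulforhodamine B assay, with a stated time of 48 h (on this read-out lower numbers stand for stronger inhibition and higher numbers for weaker inhibition), compound 1 gives 13900 nM, and compound 2 gives 23400 nM. The two differ by methoxy in place of hydrogen on an aromatic carbon, and this change produced a 1.7-fold higher number from compound 1 to compound 2 (0.23 log units; within the scatter). Compound 3, with a different core, gives 23600 nM in this assay; the difference between the core of compound 3 and that of compound 1 is not broken down here, and its value lies within the scatter of the value of compound 2.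

Compound 4, `COc1ccc2nc(-c3ccc(N/C=C\C(=O)c4cc(OC)c(OC)c([N+](=O)[O-])c4)cc3)sc2c1`, has not yet been measured. It differs from compound 3 by methoxy in place of hydrogen on an aromatic carbon. For the measured compounds named here, this is the same kind of change as the one from compound 1 to compound 2, but not the same: there the entering methoxy sat on a ring that is part of a fused or bridged system of two rings, ortho to two methoxy groups, meta and para to a fused ring, whereas here it sits on a ring of carbon only, ortho to one methoxy group, meta to a large group and meta to a nitro group.

Going by the values given here, the only precedent is the step from compound 1 to compound 2, which stayed within the scatter, and the new place is different, so the expectation rests on little. Compound 4 is expected to give about 28000 nM in this assay, between 10000 nM and 80000 nM. That corresponds to an expected step of a 1.2-fold higher number from compound 3 to compound 4 (0.07 log units; within the scatter), judged from compound 1 to compound 2 giving a 1.7-fold higher number from compound 1 to compound 2 (0.23 log units; within the scatter).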

Compound 4, half-maximal inhibitory concentration: 25600 nM
Beside the measured number, compound 4's estimate is 1.1-fold (0.04 log units) above it, and the stated range covers the measured number.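

In this assay, methoxy in place of hydrogen on an aromatic carbon produced a 1.1-fold higher number from compound 3 to compound 4 (0.04 log units; within the scatter), so this new step, like the earlier one, gives no sign that the number moved. Set side by side, the two steps agree, and within this small set the change carries from one core to the other without a readable difference: the same change on two cores in this assay, a 1.7-fold higher number (0.23 log units; within the scatter) from compound 1 to compound 2 and a 1.1-fold higher number (0.04 log units; within the scatter) from compound 3 to compound 4, 1.6-fold (0.19 log units) apart, within the scatter of two such steps. This agreement is a narrow result, since neither step stands out from the scatter, so the series shows no effect of real size that was carried over, and the entering methoxy sits in a different place in each pair, which means that core and place cannot be told apart as influences on the outcome.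

The compounds shown leave open whether any substituent at this place on the ring of carbon only can move the number beyond the scatter, for instance a hydroxy group, an amine, a carboxylic acid or a longer chain such as ethoxy in place of methoxy. They also leave open whether an amine in place of the nitro group would change how the added methoxy reads on either core.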